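The source may report more compounds than this note shows. Statements on the series, on what has been measured and on what is new or still open speak of the compounds shown alone.

Measured in an assay on isolated protein for inhibition of N-lysine methyltransferase SMYD2 (Homo sapiens); a lower number here means a stronger inhibitor, a higher number a weaker inhibitor:

compound 1 `O=C(NCCCN1CCCC1)c1cc(-c2ccccc2Cl)nc2[nH]ncc12` gives 8000 nM
compound 2 `Cc1ccccc1-c1cc(C(=O)NCCCN2CCCC2)c2c(C)n[nH]c2n1` gives 8900 nM
compound 3 `Cc1ccccc1-c1cc(C(=O)NCCCN2CCCC2)ccn1` gives 8800 nM

The three numbers sit close together. In this assay compound 3 stands between the others: its nearest neighbour is compound 2, and the gap to compound 1 is also within the usual scatter, so no order among the three can be read from these numbers. The shared pattern of a 2-methylphenyl group on the core and the pyrrolidinyl-propyl amide gives much the same number whichever core is used.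

The next compound, compound 4 `CNc1cc(C(=O)NCCCN2CCCC2)cc(-c2ccccc2C)n1`, differs from compound 3 in one place: methylamino in place of hydrogen on an aromatic carbon. Among the measured compounds shown here, no pair shows what such a change does in this assay, so the expectation rests only on the small spread seen so far. A step of modest size toward a lower number, at the edge of the scatter, is expected, with a result within the scatter of compound 3 also likely. The estimated step from compound 3 to compound 4 is a 1.5-fold lower number from compound 3 to compound 4 (0.17 log units; within the scatter). For compound 4 the expected value in this assay is 6000 nM, with a range from 2000 nM to 18000 nM.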

Compound 4, half-maximal inhibitory concentration: 17700 nM
The estimate for compound 4 lay 3.0-fold (0.47 log units) below the measured number, within the range that was stated.
By their numbers in this assay, from the lowest: compounds 1, 3, 2 and 4 (each within the scatter of the next, the first and the last beyond it).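

In this assay, among the compounds shown here, this is the first pair that differs in one place, and it gives a 2.0-fold higher number from compound 3 to compound 4 (0.30 log units; within the scatter). Methylamino on this aromatic carbon, next to the ring nitrogen, therefore brings no difference that can be told from the scatter, and the pair gives no sign of a stronger inhibitor from this change. No measurement at hand bears on the reason for the size of this step.

From the compounds shown here alone, whether a plain amino group, a dimethylamino group or a methoxy group on this same carbon would give a step beyond the scatter remains open. Also open, going by these compounds, is whether methylamino would give a similar step on the cores of compound 1 and compound 2.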